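The compounds below may be only part of what the source reports. "The series", "measured", "known", "first", "only" and "open" are said of these compounds alone.

In a functional assay on V79 cells (Cricetulus griseus) for cytotoxicity, read by colony formation (on this read-out higher numbers stand for weaker inhibition and lower numbers for stronger inhibition), compound 3 `COc1c(F)c(N2CCC(N)C2)c(Cl)c2c1c(=O)c(C(=O)O)cn2C1CC1` gives > 500 ug/mL, which is a limit and not a number. This places compound 3 at the limit of > 500 ug/mL in this assay, at which 1 of the 3 values shown sits. Compound 2 `Nc1c(F)c(N2CCC(N)C2)c(Cl)c2c1c(=O)c(C(=O)O)cn2C1CC1` gives 59 ug/mL and compound 1 `NC1CCN(c2cc3c(c(O)c2F)c(=O)c(C(=O)O)cn3C2CC2)C1` gives 72 ug/mL, two values within the usual scatter of each other. Compound 4 `NC1CCN(c2c(F)c(Cl)c3c(=O)c(C(=O)O)cn(C4CC4)c3c2Cl)C1` differs from compound 3 by chloro in place of methoxy on an aromatic carbon, with chloro in place of methoxy on an aromatic carbon, ortho to a fluoro group. Within the data shown here, only one measured step bears on this carbon: an at least 8.4-fold higher number from compound 2 to compound 3 (0.92 log units; beyond the scatter), where methoxy takes the place of amino and the change lies beyond the scatter. Among the measured compounds shown here, no measured step brings chloro onto this carbon, so the size of the change remains uncertain. With methoxy leaving, a return towards the value of compound 2 at 59 ug/mL is expected, probably only part of the way. The step expected is an at least 4.1-fold lower number from compound 3 to compound 4 (0.61 log units; beyond the scatter), towards a lower number and stronger inhibition in this assay. For compound 4 the estimated value is 120 ug/mL, with an expected range of 35 ug/mL to 400 ug/mL.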

Compound 4, half-maximal inhibitory concentration: > 500 ug/mL
Compound 4: no number, only a limit (the forecaster's own chance of this, stated with the estimate: 15%); at least 4.1-fold (0.61 log units) between middle value and limit.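

In this assay, chloro on this aromatic carbon, ortho to a fluoro group, stands apart from amino just as methoxy does (an at least 8.4-fold higher number from compound 2 to compound 4 (0.92 log units; beyond the scatter)). Compound 4 gives a limit and not a number (> 500 ug/mL). The gap to compound 2 therefore no longer rests on methoxy alone, as two different replacements of amino now reach the same limit: the limit of > 500 ug/mL in this assay, at which 2 of the 4 values shown sit.

Going by these compounds, the step from compound 3 to compound 4 cannot be read, and how far either compound lies beyond the limit remains unknown. On these data alone, whether the lower number of compound 2 is particular to amino also stays open, and a methyl or a dimethylamino group on this carbon would test that.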